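Swapping a Methoxyphenyl for a Biphenyl: Cytotoxicity Outlook

The compounds below may be only part of what the source reports. "The series", "measured", "known", "first", "only" and "open" are said of these compounds alone.

compound 1 `COC(=O)c1ccc(NCc2cncn2Cc2ccccc2OC)cc1-c1ccccc1`: "not determined" (no result reported)
compound 2 `Cc1cccc(-c2cccc(NCc3cncn3Cc3ccccc3)c2)c1`: > 1000 nM

In a toxicity assay on NIH3T3 cells (Mus musculus) for cytotoxicity, read by resazurin assay (on this read-out higher numbers stand for an effect only at larger amounts of compound and lower numbers for an effect already at smaller amounts), compound 1 has no reported number, so it cannot be placed on this read-out. Compound 2 gives > 1000 nM in this assay, which is a limit of the assay rather than a number. For the measured compounds named here, the only evidence on this read-out is the limit of > 1000 nM in this assay, at which 1 of the 2 values shown sits. Compound 3 `COC(=O)c1ccc(NCc2cncn2Cc2ccc(-c3ccccc3)cc2)cc1-c1ccccc1` keeps the core of compound 1 and differs from it by 4-phenylphenyl in place of 2-methoxyphenyl on a saturated chain carbon bound to an aromatic nitrogen. Going by the values given here, with no measured step between compounds to draw on, the change expected in this assay from compound 1 to compound 3 is none beyond the usual scatter. Compound 3 is estimated at 3000 nM, with a range from 800 nM to 20000 nM.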

Compound 3, half-maximal effective concentration: > 1000 nM
Compound 3 gave a limit, no number; the forecaster's own chance of this, stated with the estimate: 70%; the middle value does not contradict the limit.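

For the compounds shown here, compound 3 gives only a limit and compound 1 has no reported number in this assay, so no step between them can be read. As far as these compounds go, whether 4-phenylphenyl in place of 2-methoxyphenyl changes the result in this assay stays open, as does the concentration at which compound 2 or compound 3 would act.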